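The source may report more compounds than this note shows. Statements on the series, on what has been measured and on what is new or still open speak of the compounds shown alone.

Measured so far:
compound 1 `NC1=NC2(CCOCC2)N(OCCCOc2ccc(Cl)cc2)C(N)=N1` 360 nM
compound 2 `NC1=NC2(CCOCC2)N(OCCCOc2ccc(Cl)cc2Cl)C(N)=N1` 70 nM
compound 3 `COc1ccc(OCCCON2C(N)=NC(N)=NC23CCOCC3)cc1` 660 nM

In a functional assay on A549 cells (Homo sapiens) for antiproliferative activity, read by MTT assay, with a stated time of 72 h (a lower number here means a stronger inhibitor, a higher number a weaker inhibitor), compound 3 gives the highest of the three numbers; compound 1 lies nearest, within the scatter, and compound 2 furthest, with a 9.4-fold higher number from compound 2 to compound 3 (0.97 log units; beyond the scatter) beyond the scatter. Compound 4 `Cc1cc(C)cc(OCCCON2C(N)=NC(N)=NC23CCOCC3)c1` differs from compound 3 by 3,5-dimethylphenyl in place of 4-methoxyphenyl on an oxygen on a saturated carbon. Going by the values given here, no measured step carries a methyl on this ring. The replacement of the aryl group gave a 9.4-fold higher number from compound 2 to compound 3 (0.97 log units; beyond the scatter), while a 1.8-fold higher number from compound 1 to compound 3 (0.26 log units; within the scatter) stayed within the scatter; the added chloro gave a 5.1-fold lower number from compound 1 to compound 2 (0.71 log units; beyond the scatter). A second ring substituent is the only analogy, so a modest lower number is expected for compound 4, estimated at 280 nM (range 90 nM to 900 nM), that is an expected step of a 2.4-fold lower number from compound 3 to compound 4 (0.37 log units; beyond the scatter).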

Compound 4, half-maximal inhibitory concentration: 710 nM
Beside the measured number, compound 4's estimate is 2.5-fold (0.40 log units) below it, within the range that was stated.
By their numbers in this assay, from the lowest: compound 2; then compounds 1, 3 and 4 (each within the scatter of the next).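

In this assay, 3,5-dimethylphenyl in place of 4-methoxyphenyl gives a 1.1-fold higher number from compound 3 to compound 4 (0.03 log units; within the scatter) so trading one hydrogen-bond acceptor for none on this aryl group leaves the number level. 3,5-dimethylphenyl also stays level with 4-chlorophenyl in a 2.0-fold higher number from compound 1 to compound 4 (0.29 log units; within the scatter) while a 10-fold higher number from compound 2 to compound 4 (1.01 log units; beyond the scatter) leaves 2,4-dichlorophenyl alone apart from the other three aryl groups. No measurement at hand accounts for that gap.

Open, from the compounds shown here alone, is whether an amine or a carboxylic acid on this ring would hold the number or move it, and what a longer chain would do.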